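The source may hold more compounds than are shown below. What is called first, only, known or untested is meant among the compounds shown, and "the series" means these compounds.

In a functional assay on PC-3 cells (Homo sapiens) for cytotoxicity, read by sulforhodamine B assay, with a stated time of 48 h (on this read-out higher numbers stand for weaker inhibition of growth and lower numbers for stronger inhibition of growth), the measured compounds stand as follows: compound 1 `ClCc1ccc(Cn2cnc3c(Cl)ncnc32)cc1` gives 4780 nM; compound 2 `Nc1nc(Cl)c2ncn(Cc3ccc(CCl)cc3)c2n1` gives 7410 nM; compound 3 `ClCc1ccccc1Cn1cnc2c(Cl)ncnc21` gives 3020 nM.

From compound 1 to compound 2 the change is amino in place of hydrogen on an aromatic carbon, and in this assay it gave a 1.6-fold higher number from compound 1 to compound 2 (0.19 log units; within the scatter). Compound 4 `Nc1nc(Cl)c2ncn(Cc3ccccc3CCl)c2n1` carries the same change relative to compound 3, namely (amino in place of hydrogen on an aromatic carbon). The difference between the core of compound 1 and the core of compound 3 is not broken down here; the two cores share the same atoms joined differently.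

For compound 4 a step of about a 1.6-fold higher number from compound 3 to compound 4 (0.20 log units; within the scatter) is expected, because a 1.6-fold higher number from compound 1 to compound 2 (0.19 log units; within the scatter) was itself within the scatter. Compound 4 is therefore estimated at 4800 nM, with a likely range from 2500 nM to 9500 nM.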

Compound 4, concentration for 50% growth inhibition: 15100 nM
Estimate against measurement, compound 4: 3.1-fold (0.50 log units) below; measured number above the stated range.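

In this assay, amino in place of hydrogen on an aromatic carbon gave a 5.0-fold higher number from compound 3 to compound 4 (0.70 log units; beyond the scatter), and the step did not keep its size from one core to the other: the same change on two cores in this assay, a 1.6-fold higher number (0.19 log units; within the scatter) from compound 1 to compound 2 and a 5.0-fold higher number (0.70 log units; beyond the scatter) from compound 3 to compound 4, 3.2-fold (0.51 log units) apart, beyond the scatter of two such steps. Within the data shown here, the number rises on both cores, but only the step on the core of compound 3 lies beyond the scatter, so a clear loss of growth inhibition is seen on that core alone. Two pairs do not show why the cores differ, nor what the change would do on a further core.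

The compounds shown leave open what a methylamino group or a hydroxyl group would do on the same carbon. They also leave open whether the chloromethyl group could give way to a hydroxymethyl group without changing the size of the amino step.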